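A Methyl for an Iodine on a Thio-Sugar Nucleoside

The source may hold more compounds than are shown below. What is called first, only, known or untested is meant among the compounds shown, and "the series" means these compounds.

Compound 1 `O=c1[nH]c(=O)n([C@H]2S[C@H](CO)[C@@H](O)[C@@H]2O)cc1I` was tested in a functional assay on CCRF-HSB-2 cells (Homo sapiens) for antiproliferative activity; a higher number here means a weaker inhibitor, a lower number a stronger inhibitor. In this assay compound 1 reaches only the limit of > 100 ug/mL, a boundary of the measurement rather than a number. Compound 2 `Nc1nc(N)c2ncn([C@H]3C[C@H](O)[C@@H](CO)O3)c2n1` shares neither the sugar nor the base with compound 1; in this assay compound 2 gives 1.7 ug/mL. Within the data shown here, the two cannot be joined by a single step, and the only evidence at hand is the limit of > 100 ug/mL in this assay, at which 1 of the 2 values shown sits. Compound 3 `Cc1cn([C@H]2S[C@H](CO)[C@@H](O)[C@@H]2O)c(=O)[nH]c1=O` differs from compound 1 in one place: methyl in place of iodo on an aromatic carbon. Among the measured compounds shown here, no measured pair shows what such a swap does here, so the step cannot be read off any neighbour. For compound 3 the expectation is a step of an at least 1.2-fold lower number from compound 1 to compound 3 (0.09 log units; that floor lies within the scatter), not beyond the usual scatter, leaning toward a stronger inhibitor if anything. The estimate for compound 3 in this assay is 80 ug/mL, with a likely range from 20 ug/mL to 200 ug/mL.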

Compound 3, half-maximal inhibitory concentration: 42 ug/mL
Compound 3: middle estimate off by 1.9-fold (0.28 log units), on the high side; the range from low to high includes it.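

Methyl in place of iodo on this aromatic carbon gives the first readable step at this position in this assay: an at least 2.3-fold lower number from compound 1 to compound 3 (0.37 log units; beyond the scatter). The position therefore responds to the group it carries, and with the sugar and the rest of the base unchanged, the methyl compound is the stronger inhibitor of the pair, by a step beyond the usual scatter. The printed size is only a floor, since compound 1 stands at a limit and the full step cannot be read from it: the limit of > 100 ug/mL in this assay, at which 1 of the 3 values shown sits.

On these data alone, what an ethyl group, a longer chain, an amine or a chlorine would do on this same carbon stays open. Compound 2 shares neither the sugar nor the base with compound 1, so it says nothing about this position.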